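Pyrimidine for pyridine on a weakly cytotoxic anilide

A few compounds are considered here, and "the series" means these few. Any claim that something is new, unique, unknown or untested is made for them only; others in the source may bear on it.

Compound 1 `Cc1ccc(C(=O)Nc2ccc(CN3CCN(C)CC3)c(C(F)(F)F)c2)cc1Nc1cc(-c2cccnc2)ccn1` was tested in a toxicity assay on HEK293 cells (Homo sapiens) for cytotoxicity, read by MTT assay, with a stated time of 48 h (a lower number here means a stronger inhibitor, a higher number a weaker inhibitor), where compound 1 gives 14000 nM. Among the compounds with values here, this is the only number reported in this assay; the other entry is a limit. Compound 2 `Cc1ccc(C(=O)Nc2cc(-c3cnn(C)c3)cc(C(F)(F)F)c2)cc1Nc1cc(-c2cncnc2)ccn1` does not give a number in this assay but only a limit, > 80000 nM. For this assay it is worth noting (the limit of > 80000 nM in this assay, at which 1 of the 2 values shown sits). Within the data shown here, compound 2 carries the pyrimidin-5-yl group that appears in compound 3, but it differs from compound 3 in more than one place, so it offers no single step and its limit says only that its cytotoxicity was not measurable.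

Compound 3 `Cc1ccc(C(=O)Nc2ccc(CN3CCN(C)CC3)c(C(F)(F)F)c2)cc1Nc1cc(-c2cncnc2)ccn1` differs from compound 1 in one place: pyrimidin-5-yl in place of pyridin-3-yl on an aromatic carbon. Among the measured compounds shown here, no measured pair differing only in this way is available, so the size of the step is not known from the data. The expectation is that the step from compound 1 to compound 3, a 1.4-fold higher number from compound 1 to compound 3 (0.15 log units; within the scatter), is small, toward weaker inhibition or none beyond the scatter. Compound 3 is accordingly estimated at 20000 nM, with a range from 7000 nM to 80000 nM.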

Compound 3, half-maximal inhibitory concentration: 17100 nM
The estimate for compound 3 lay 1.2-fold (0.07 log units) above the measured number; the range from low to high includes it.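

In this assay the exchange of pyridin-3-yl for pyrimidin-5-yl, on an aromatic carbon opposite the ring nitrogen, now has a measured size: a 1.2-fold higher number from compound 1 to compound 3 (0.09 log units; within the scatter). The two compounds therefore cannot be told apart in this read-out, although the entering ring has one more ring nitrogen and one more hydrogen-bond acceptor by count; this is the only comparison shown that differs in one place, so the finding holds for this single change on the core of compound 1 and no further. Nothing shown here speaks to why the two compounds read alike.

As far as these compounds go, it remains open whether another group at this place, such as a phenyl ring with no ring nitrogen, a ring carrying an amine or one carrying a carboxylic acid, would give a number beyond the scatter from that of compound 1. Compound 2 gives only a limit, > 80000 nM, and it differs from compound 3 in more than one place, so which of its differences accounts for that entry also stays open.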